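The source may hold more compounds than are shown below. What is called first, only, known or untested is meant among the compounds shown, and "the series" means these compounds.

In an ADME assay on microsomes from liver (Mus musculus) for metabolic stability, read by LC-MS, with NADPH named in the record, with a stated time of 60 min, tested at 1 uM, in the absence of a further agent (on this read-out lower numbers stand for a less stable compound and higher numbers for a more stable compound), three compounds on the shared core have been measured. Compound 1 `COc1ccc(-c2c(C)nc3c(N4CC[C@@H](NS(=O)(=O)c5ccccc5)C4)cc(C)nn23)cc1OC` gives > 95%, which is a limit of the assay and not a number. Compound 2 `COc1ccc(-c2c(C)nc3c(N4CCCC4)cc(C)nn23)cc1OC` gives > 95%, again a limit. Compound 3 `COc1ccc(-c2c(C)nc3c(N4CC=CC4)cc(C)nn23)cc1OC` gives > 95%, also a limit. The three therefore stand together, with the limit of > 95% in this assay, at which 3 of the 3 values shown sit.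

Compound 4 `COc1ccc(-c2c(C)nc3c(N4CC[C@@H](SC(C)=O)C4)cc(C)nn23)cc1OC` has not yet been measured. Its change from compound 3 is a group of 9 heavy atoms (6 carbon, 1 nitrogen, 1 oxygen, 1 sulfur; one five-membered non-aromatic ring with 1 hetero atom) in place of a group of 5 heavy atoms (4 carbon, 1 nitrogen; one five-membered non-aromatic ring with 1 hetero atom), on an aromatic carbon: the 3-(acetylsulfanyl)pyrrolidin-1-yl group enters on an aromatic carbon.

The measured steps offer no size to carry over. One is a step that the two limits leave unreadable from compound 1 to compound 2, which concerns a group on the saturated ring, and the other is a step that the two limits leave unreadable from compound 2 to compound 3, which swaps one five-membered non-aromatic ring for another. Within the data shown here, no compound measured so far carries an acetylsulfanyl group. Among the measured compounds shown here, compound 1 holds a large group on its ring and still reports > 95%, which points to a small change at most, although that limit is only one example. A fall is the only direction that can be seen from a limit at this end of the scale. The expected change is a number at least 7 percentage points lower from compound 3 to compound 4 (that floor lies within the scatter), a modest and uncertain estimate. For compound 4 the estimated value is 88%, with an expected range from 60% to 99%.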

Compound 4, percent of the compound remaining: > 95%
Compound 4: no number, only a limit; the forecaster's own chance of this, stated with the estimate: 45%; middle value at least 7 percentage points away from the limit.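

In this assay compound 4 gives > 95%, which is a limit of the assay and not a number. No step from compound 1, compound 2 or compound 3 to compound 4 can be read, because all of these compounds stop at the same limit: the limit of > 95% in this assay, at which 4 of the 4 values shown sit.

The compounds shown leave open whether the 3-(acetylsulfanyl)pyrrolidin-1-yl group changes the percent remaining at all, and how the four compounds rank against one another.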